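Series notes: chloro step from compound 2 to compound 3

The source may report more compounds than this note shows. Statements on the series, on what has been measured and on what is new or still open speak of the compounds shown alone.

Measured so far:
compound 1 `Nc1scc(-c2cccc(F)c2)c1C(=O)c1ccccc1`: 52%
compound 2 `Nc1scc(-c2ccc(F)cc2)c1C(=O)c1ccccc1`: 60%

In a functional assay on CHO cells for agonist activity at adenosine receptor A1 (Homo sapiens), read by fluorescence and ERK phosphorylation, with stated times of 30 min and 1.5 h, tested at 10 uM (a higher number here means a stronger effect of the compound at the concentration tested, a lower number a weaker effect), compound 2 gives 60%. Going by the values given here, the only other number, from compound 1 at 52%, lies within the scatter of it; the one measured step, a number 8 percentage points higher from compound 1 to compound 2 (within the scatter), is within the scatter. Compound 3 `Nc1scc(-c2ccc(F)cc2)c1C(=O)c1ccc(Cl)cc1` differs from compound 2 by chloro in place of hydrogen on an aromatic carbon. Among the compounds with values here, the measured step alters the fluorophenyl on the core and leaves the phenyl of the carbonyl untouched, so no measured step bears directly on the change from compound 2 to compound 3. Within the data shown here, with the single step seen being within the scatter and no data on the carbonyl-side phenyl, no step beyond the scatter is expected in this assay in either direction. Compound 3 is therefore estimated at 60%, with a range from 40% to 80%. The expected step of no change at the digits printed from compound 2 to compound 3 (within the scatter) is thus within the scatter.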

Compound 3, a percentage reported as activity, at one concentration (the size of the read-out at that concentration, not a potency): 61%
For compound 3 the middle estimate is 1 percentage points below the measured one; the measured number falls inside the stated range.
By their numbers in this assay, from the lowest: compounds 1, 2 and 3 (each within the scatter of the next).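

Going by these compounds alone, the step at the phenyl of the carbonyl, a number 1 percentage points higher from compound 2 to compound 3 (within the scatter), in this assay, is the only measured change on that side of the shared core; the earlier step touched only the fluorophenyl. At this place, para to a large group, phenyl to 4-chlorophenyl leaves the read-out within the scatter, so a single chlorine atom on that ring is compatible with activity at the tested concentration. No available evidence explains this result.

From the compounds shown here alone, whether this holds beyond chloro remains open: a methoxy group, an amine or a carboxylic acid at the same place could give a different reading. With each compound read at one concentration, the compounds shown also leave their potencies open.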